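The source may report more compounds than this note shows. Statements on the series, on what has been measured and on what is new or still open speak of the compounds shown alone.

In an ADME assay on MDBK cells (Bos taurus) for cytotoxicity (on this read-out higher numbers stand for lower toxicity in this test and lower numbers for higher toxicity in this test), compound 1 (`CC(C)N(CCn1ccc2nc(-c3ccccc3)nc-2c1)C(C)C`) gives > 100000 nM, which is a limit. Compound 2 (`c1ccc(-c2nc3ccn(Cc4cccnc4)cc-3n2)cc1`) gives > 100000 nM, also a limit, so its position in the series has no exact number. Within the data shown here, the only measured step is a step that the two limits leave unreadable from compound 1 to compound 2, and the sole evidence is the limit of > 100000 nM in this assay, at which 2 of the 2 values shown sit. Compound 3 (`Clc1ccc(Cn2ccc3nc(-c4ccccc4)nc-3c2)s1`) carries 5-chlorothiophen-2-yl in place of pyridin-3-yl on a saturated chain carbon bound to an aromatic nitrogen, with 5-chlorothiophen-2-yl in place of pyridin-3-yl. Among the measured compounds shown here, with no step of readable size to draw on, only a modest move towards lower numbers in this assay is expected, and the estimated step is an at least 1.4-fold lower number from compound 2 to compound 3 (0.15 log units; that floor lies within the scatter). The estimate for compound 3 is 70000 nM, with an expected range of 20000 nM to 150000 nM.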

Compound 3, half-maximal cytotoxic concentration: > 100000 nM
Compound 3 gave a limit, no number; the forecaster's own chance of this, stated with the estimate: 50%; at least 1.4-fold (0.15 log units) between middle value and limit.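

Compound 3 gives > 100000 nM in this assay, a limit and not a number, so its steps from compound 1 and compound 2 cannot be read. From the compounds shown here alone, whether any group on this saturated chain carbon gives a readable value in this assay remains open.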